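Nitrile for Amide on the Aryl Ring of Compound 3

The source may report more compounds than this note shows. Statements on the series, on what has been measured and on what is new or still open speak of the compounds shown alone.

Of the compounds shown here, three built on one shared core have been measured in a functional assay on NCI-H460 cells (Homo sapiens) for antiproliferative activity, with a stated time of 72 h; on this read-out higher numbers stand for weaker inhibition and lower numbers for stronger inhibition. Compound 1 `C=CC[C@H]1C[C@]2([C@@H](C)Cc3ccc(OC)c(OC)c3)OCOC2=CC1=O` gives 260 nM in this assay. Compound 2 `C=CC[C@H]1C[C@]2([C@@H](C)Cc3ccc(OC)c(C)c3)OCOC2=CC1=O` gives 630 nM in this assay, and the step is a 2.4-fold higher number from compound 1 to compound 2 (0.38 log units; beyond the scatter). Compound 3 `C=CC[C@H]1C[C@]2([C@@H](C)Cc3ccc(OC)c(C(N)=O)c3)OCOC2=CC1=O` gives 66 nM in this assay and stands lowest of the three numbers, with both other compounds beyond the scatter from it.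

Compound 4 `C=CC[C@H]1C[C@]2([C@@H](C)Cc3ccc(OC)c(C#N)c3)OCOC2=CC1=O` differs from compound 3 in one place: cyano in place of carbamoyl on an aromatic carbon. For the measured compounds named here, the steps that bear on this change are the two that brought the carbamoyl in, a 3.9-fold lower number from compound 1 to compound 3 (0.60 log units; beyond the scatter) and a 9.5-fold lower number from compound 2 to compound 3 (0.98 log units; beyond the scatter), each of them lowering the number by a modest amount. The cyano group keeps one hydrogen-bond acceptor but carries no hydrogen-bond donor, whereas the carbamoyl counted one of each, so compound 4 is expected to keep part, not all, of the advantage seen for compound 3 in a 3.9-fold lower number from compound 1 to compound 3 (0.60 log units; beyond the scatter). The expected step is therefore a modest rise, a 2.3-fold higher number from compound 3 to compound 4 (0.36 log units; beyond the scatter). Compound 4 is estimated at 150 nM in this assay, with a range from 50 nM to 450 nM.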

Compound 4, half-maximal inhibitory concentration: 340 nM
Beside the measured number, compound 4's estimate is 2.3-fold (0.36 log units) below it; measured number inside the range.
By their numbers in this assay, from the lowest: compound 3; then compounds 1, 4 and 2 (each within the scatter of the next, the first and the last beyond it).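

In this assay, the cyano group does not hold the advantage of the carbamoyl at this aromatic carbon, ortho to a methoxy group, as shown by a 5.2-fold higher number from compound 3 to compound 4 (0.71 log units; beyond the scatter) on this change. Compound 4 instead falls in with the compounds lacking the carbamoyl, with a 1.9-fold lower number from compound 2 to compound 4 (0.27 log units; within the scatter) and a 1.3-fold higher number from compound 1 to compound 4 (0.12 log units; within the scatter), even though those two compounds are themselves separated by a 2.4-fold higher number from compound 1 to compound 2 (0.38 log units; beyond the scatter); among the four groups tried here, only the carbamoyl stands clear of all the others. The hydrogen-bond donor leaves with the carbamoyl while the hydrogen-bond acceptor count stays the same, but nothing available connects that difference in counts to the loss in this assay, so it remains an observation and not an explanation.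

The compounds shown leave open whether a carboxylic acid, an N-methyl amide or an aminomethyl group on this aromatic carbon would come close to compound 3 at 66 nM in this assay or would fall with compound 4. They also leave open whether the carbamoyl would keep its lead with an ethoxy group in place of the methoxy group.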